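Ether versus ester at the side-chain oxygen

The compounds below may be only part of what the source reports. "The series", "measured", "known", "first", "only" and "open" are said of these compounds alone.

Among the measured compounds shown here, the series shares the core of compound 2 `C=CCC(=O)O[C@H]1C[C@@H](C)C=C2C=C[C@H](C)[C@H](CCC3C[C@@H](O)CC(=O)O3)[C@H]21`, which in an assay for inhibition of 3-hydroxy-3-methylglutaryl-coenzyme A reductase (Rattus norvegicus) (on this read-out higher numbers stand for weaker inhibition and lower numbers for stronger inhibition), gives 2.9 nM, the lowest of the two numbers so far. Compound 1 `C=C(C)CO[C@H]1C[C@@H](C)C=C2C=C[C@H](C)[C@H](CCC3C[C@@H](O)CC(=O)O3)[C@H]21` carries an ether in place of the ester and gives 360 nM in this assay. For the measured compounds named here, the one measured step, a 120-fold lower number from compound 1 to compound 2 (2.09 log units; beyond the scatter), links them.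

Compound 3 `CO[C@H]1C[C@@H](C)C=C2C=C[C@H](C)[C@H](CCC3C[C@@H](O)CC(=O)O3)[C@H]21` is not yet measured. Relative to compound 2 the change is methyl in place of allylcarbonyl on an oxygen on a saturated carbon. Going by the values given here, the ester is thus replaced by an ether, the reverse direction of the one measured step, which was a large move toward a lower number when the ether of compound 1 became the ester of compound 2. Among the compounds with values here, no pair compares the two ethers of compound 1 and compound 3 directly, so the size of the 2-methylprop-2-en-1-yl group against methyl is unknown.

A step to a markedly higher number in this assay is therefore expected from compound 2 to compound 3, of roughly a 170-fold higher number from compound 2 to compound 3 (2.24 log units; beyond the scatter), because the ester-to-ether move mirrors a 120-fold lower number from compound 1 to compound 2 (2.09 log units; beyond the scatter). Compound 3 is estimated at 500 nM, within 100 nM to 3000 nM.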

Compound 3, half-maximal inhibitory concentration: 2810 nM
For compound 3 the middle estimate is 5.6-fold (0.75 log units) below the measured one; the range from low to high includes it.
By their numbers in this assay, from the lowest: compound 2; then compound 1; then compound 3.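

Against the ester of compound 2, the methoxy group of compound 3 gives a 970-fold higher number from compound 2 to compound 3 (2.99 log units; beyond the scatter) in this assay, so both ethers now stand on the high side of the ester, with no compound shown going against that order. The ethers also differ from each other, with a 7.8-fold higher number from compound 1 to compound 3 (0.89 log units; beyond the scatter) as a modest step beyond the scatter, so the result at this oxygen depends on the group carried by the ether as well as on the ether linkage itself. Among the compounds shown here, of the two measured ethers, the one with the 2-methylprop-2-en-1-yl group stands closer to the ester, while the bare methyl ether gives the highest number of the series, and no measurement at hand explains either step.

The change from allylcarbonyl to methyl removes the carbonyl and shortens the group together, so these compounds do not separate the two changes; an acetyl ester or a butyl ether would bear directly on that split. As far as these compounds go, the free hydroxyl at this position, and an amide or carbamate carrying an amine nitrogen, also remain open, as does any longer or branched ester chain.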